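The compounds below may be only part of what the source reports. "The series", "measured", "known", "first", "only" and "open" are said of these compounds alone.

In an assay on CHO-K1 cells for displacement of a labelled ligand from melanin-concentrating hormone receptor 1 (Homo sapiens), read by scintillation proximity assay, with a stated time of 2 h (a lower number here means a stronger inhibitor, a higher number a weaker inhibitor), compound 1 `Cc1nc(N(C)C2CCCC2)nc2ccc(NC(=O)/C=C/c3ccc(Cl)cc3)cc12` gives 399 nM, the second highest of the three numbers recorded so far. Its nearest neighbour is compound 2 `C/C(=C\C(=O)Nc1ccc2nc(N3CCC(O)CC3)nc(C)c2c1)c1ccc(Cl)cc1`, which gives 670 nM, a gap within the usual scatter of such measurements, while compound 3 `Cc1nc(N2CCC(NS(=O)(=O)N(C)C)CC2)nc2ccc(NC(=O)/C=C/c3ccc(OC(F)(F)F)cc3)cc12` gives 105 nM, a gap beyond that scatter. Compound 4 `CCCC1(O)CCN(c2nc(C)c3cc(NC(=O)/C=C/c4ccc(Cl)cc4)ccc3n2)CC1` has not yet been measured in this assay. It differs from compound 1 in one place: 4-hydroxy-4-propylpiperidin-1-yl in place of cyclopentyl(methyl)amino on an aromatic carbon, on an aromatic carbon of the shared core between two ring nitrogen atoms. Going by the values given here, no measured pair isolates this exchange, so its size must be guessed. For compound 4 the expected step is a 1.3-fold lower number from compound 1 to compound 4 (0.12 log units; within the scatter), none beyond the scatter. The estimate for compound 4 in this assay is 300 nM, within a range of 80 nM to 1100 nM.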

Compound 4, half-maximal inhibitory concentration: 245 nM
Beside the measured number, compound 4's estimate is 1.2-fold (0.09 log units) above it; low and high end bracket the measured number.
By their numbers in this assay, from the lowest: compound 3; then compounds 4, 1 and 2 (each within the scatter of the next, the first and the last beyond it).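

In this assay, 4-hydroxy-4-propylpiperidin-1-yl in place of cyclopentyl(methyl)amino, on the aromatic carbon between two ring nitrogen atoms, gives a 1.6-fold lower number from compound 1 to compound 4 (0.21 log units; within the scatter) and so shows that this position accepts the larger group, with its hydroxy-bearing six-membered ring, without a change beyond the scatter. Going by these compounds alone, this is the first pair to isolate a change at this position. Nothing measured here bears on the cause of this step. From the compounds shown here alone, it remains open whether the hydroxy group or the propyl chain matters to this result. An amine or a carboxylic acid in place of that hydroxy group, or a longer chain in place of propyl, could still move the number.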